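Methyl in Place of Bromo on the Shared Core

The source may hold more compounds than are shown below. What is called first, only, known or untested is meant among the compounds shown, and "the series" means these compounds.

The account concerns two measured compounds and one awaiting measurement in a functional assay on HT-29 cells (Homo sapiens) for inhibition, read by MTT assay, with a stated time of 72 h; on this read-out lower numbers stand for stronger inhibition and higher numbers for weaker inhibition. Compound 1 `CCN(CC)CCCn1c(=O)c(=Cc2ccccc2O)s/c1=C1\C(=O)Nc2ccc(Br)cc21` gives 18100 nM in this assay. Compound 2 `CN(C)CCn1c(=O)c(=Cc2ccc(C=O)c(C=O)c2)s/c1=C1\C(=O)Nc2cc(F)ccc21` gives 1360 nM in this assay, a lower number, and the gap between the two is beyond the scatter; the two compounds differ in more than one place, so nothing is drawn from that gap about any single change. Among the two numbers, compound 1 stands highest.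

Compound 3 `CCN(CC)CCCn1c(=O)c(=Cc2ccccc2O)s/c1=C1\C(=O)Nc2ccc(C)cc21` differs from compound 1 in one place: methyl in place of bromo on an aromatic carbon, where the bromo sits on an aromatic carbon of a six-membered aromatic ring of carbon only, part of a fused or bridged system of two rings. Nothing measured shows what this exchange does on this core, so the expectation rests on compound 1 alone. The step of a 1.1-fold higher number from compound 1 to compound 3 (0.04 log units; within the scatter) is expected to stay within the scatter, with no preferred direction. Compound 3 is accordingly expected to give about 20000 nM in this assay, with a range from 6000 nM to 60000 nM.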

Compound 3, half-maximal inhibitory concentration: 8070 nM
The estimate for compound 3 lay 2.5-fold (0.39 log units) above the measured number, and the stated range covers the measured number.
By their numbers in this assay, from the lowest: compound 2; then compound 3; then compound 1.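

On the shared core, methyl in place of bromo on an aromatic carbon, meta to a fused ring and para to a fused ring, gives a 2.2-fold lower number from compound 1 to compound 3 (0.35 log units; beyond the scatter) in this assay, a modest step but one beyond the scatter. Going by these compounds alone, this is the first comparison here that isolates a single change, and it shows that the number responds to the group at this carbon even when one heavy atom replaces another and the counted hydrogen-bond donors, hydrogen-bond acceptors and net charge stay the same. No measurement presented here bears on what lies behind this step.

The compounds shown leave open whether a chloro, a methoxy or an amine on this carbon would lower the number further or raise it, since only bromo and methyl can be compared here. They also leave open whether the exchange would give a similar step with a different side chain on the core, such as the dimethylaminoethyl chain of compound 2, which differs from the other compounds in more than one place.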